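This account rests on a few compounds, and the source may have more. Where it says the series, first, only, none or still open, it means among the compounds named here.

In a functional assay on A-431 cells (Homo sapiens) for antiproliferative activity, read by sulforhodamine B assay, with a stated time of 72 h (on this read-out higher numbers stand for weaker inhibition and lower numbers for stronger inhibition), compound 1 `C=C1CC(CBr)(c2ccccc2)OC1=O` gives 1480 nM and compound 2 `C=C1CC(CBr)(c2ccc(C(F)(F)F)cc2)OC1=O` gives 1010 nM, so the two values lie within the scatter of each other. Compound 3 `C=C1CC(CBr)(c2ccc(Cl)cc2)OC1=O` has chloro in place of trifluoromethyl on an aromatic carbon. For the measured compounds named here, the only measured step that bears on this change is trifluoromethyl in place of hydrogen on an aromatic carbon, a 1.5-fold lower number from compound 1 to compound 2 (0.17 log units; within the scatter), so no step beyond the scatter is expected in this assay. Compound 3 is estimated at 1200 nM, with an expected range of 600 nM to 2400 nM. This estimate means an expected 1.2-fold higher number from compound 2 to compound 3 (0.07 log units; within the scatter).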

Compound 3, half-maximal inhibitory concentration: 1100 nM
For compound 3 the middle estimate is 1.1-fold (0.04 log units) above the measured one, and the stated range covers the measured number.
By their numbers in this assay, from the lowest: compounds 2, 3 and 1 (each within the scatter of the next).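

With chloro on this aromatic carbon, this assay shows a 1.1-fold higher number from compound 2 to compound 3 (0.04 log units; within the scatter) and a 1.3-fold lower number from compound 1 to compound 3 (0.13 log units; within the scatter). A second group at this place, with one heavy atom rather than four, thus stays within the scatter of both trifluoromethyl and hydrogen, so the three compounds cannot be told apart here. No evidence is available to explain this. The compounds shown leave open whether an amine or a carboxylic acid on the same carbon would give a step beyond the scatter.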